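The source may report more compounds than this note shows. Statements on the series, on what has been measured and on what is new or still open speak of the compounds shown alone.

Measured compounds in the series:

Compound 1, `O=C(O)c1ccc2oc(Cn3ccnc3)cc2c1`, in an assay for inhibition of Thromboxane-A synthase (Homo sapiens) (a higher number here means a weaker inhibitor, a lower number a stronger inhibitor), compound 1 gives 12 nM.
Compound 2, `Cc1c(Cn2ccnc2)sc2ccc(C(=O)O)cc12`, in this assay compound 2 gives 17 nM.

Compound 2 carries the higher of the two numbers, but the gap to compound 1 lies within the scatter of repeated measurements, so the two compounds are to be read as equivalent in this assay; no order between them can be claimed.

The next compound, compound 3, `CSc1c(Cn2ccnc2)sc2ccc(C(=O)O)cc12`, keeps the core of compound 2 and changes one group: methylsulfanyl in place of methyl on an aromatic carbon. Within the data shown here, no measured pair shows the effect of such a change, so the expected size of the step in this assay can only be a guess. The expectation is for a step of no more than the scatter, in either direction, with the number most likely staying close to that of compound 2.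

For compound 3 the estimated value in this assay is 20 nM, with a range from 8 nM to 50 nM. The estimated step of a 1.2-fold higher number from compound 2 to compound 3 (0.07 log units; within the scatter) is accordingly expected to be small.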

Compound 3, half-maximal inhibitory concentration: 43 nM
Estimate against measurement, compound 3: 2.2-fold (0.33 log units) below, and the stated range covers the measured number.
By their numbers in this assay, from the lowest: compounds 1 and 2 (each within the scatter of the next); then compound 3.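

In this assay, among these compounds, the aromatic carbon next to the ring atom that bears the (1H-imidazol-1-yl)methyl group gives the first step beyond the scatter: methylsulfanyl in place of methyl produces a 2.5-fold higher number from compound 2 to compound 3 (0.40 log units; beyond the scatter), a modest move towards weaker inhibition. This position is therefore not indifferent to the group it carries, although that reading rests on this single pair and the size of the step remains modest. Nothing measured here accounts for the step.

The compounds shown leave open whether the number follows the sulfur atom or simply the larger group, and a methoxy or an ethyl group on the same carbon would separate these two readings. Also open, from the compounds shown here alone, is how far the number depends on having any group here at all, which a bare hydrogen would show, and whether a chlorine atom, as a single-atom replacement for methyl, would stay within the scatter of compound 2.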